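The source may report more compounds than this note shows. Statements on the series, on what has been measured and on what is new or still open speak of the compounds shown alone.

Measured so far in a functional assay on the whole organism (strain Wistar albino) for inhibition, with Rattus norvegicus as the target, read by paw edema, with stated times of 1 h and 2 h, at a dose of 40 mg/kg by the oral route; a lower number here means less inhibition, a higher number more inhibition at the dose given (going by the name of the read-out):
compound 1, `Cc1nc(Cc2ccc(Cl)cc2)sc1C1SCC(=O)N1c1ccc(F)c(Cl)c1`, gives 45.1%;
compound 2, `Cc1ccc(N2C(=O)CSC2c2sc(Cc3ccc(Cl)cc3)nc2C)cc1`, gives 61.4%;
compound 3, `COc1ccc(N2C(=O)CSC2c2sc(-c3ccccc3)nc2C)cc1`, gives 48.2%.

Compound 3 stands second highest of these three numbers. Its nearest neighbour is compound 1, lower by an amount within the usual scatter, so the two cannot be told apart; its furthest neighbour is compound 2, higher by an amount beyond the scatter.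

Compound 4, `COc1ccc(N2C(=O)CSC2c2sc(Cc3ccc(Cl)cc3)nc2C)cc1`, has not been measured yet. It differs from compound 3 in one place: 4-chlorobenzyl in place of phenyl on an aromatic carbon.

Among the compounds with values here, only one step between compounds that differ in a single place has been measured, a number 16.3 percentage points higher from compound 1 to compound 2 (beyond the scatter). That step concerns the group on the amide-type nitrogen, not the aromatic carbon that changes here, so it does not bear directly on the present change. Compound 2 does carry the 4-chlorobenzyl group that enters in compound 4, but compound 2 and compound 3 differ in two places, so their two values alone cannot separate the two changes.

Within the data shown here, with no direct precedent, a step in this assay of no more than modest size is expected, its direction uncertain and leaning slightly upward. Compound 4 is expected to give 54%, within a range from 42% to 66%. The expected step is therefore a number 5.8 percentage points higher from compound 3 to compound 4 (within the scatter).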

Compound 4, a percentage reported as inhibition, in the whole organism at one dose (the size of the read-out at that dose, not a potency): 28.6%
Compound 4: the middle estimate sits 25.4 percentage points above what was measured; the whole stated range lies above it.
By their numbers in this assay, from the lowest: compound 4; then compounds 1 and 3 (each within the scatter of the next); then compound 2.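

In this assay, with 4-methoxyphenyl on the amide-type nitrogen, changing the group on the aromatic carbon from phenyl to 4-chlorobenzyl gives a number 19.6 percentage points lower from compound 3 to compound 4 (beyond the scatter), so this position clearly affects the read-out and this change lowers it rather than raising it. With 4-chlorobenzyl held constant, the group on the nitrogen matters as well: methoxy in place of methyl on that aromatic ring gives a number 32.8 percentage points lower from compound 2 to compound 4 (beyond the scatter), and 4-methoxyphenyl in place of 3-chloro-4-fluorophenyl gives a number 16.5 percentage points lower from compound 1 to compound 4 (beyond the scatter), so among these three compounds the 4-methoxyphenyl group pairs worst with 4-chlorobenzyl, although it gave a number that could not be told from that of compound 1 when paired with phenyl in compound 3. Nothing measured here explains why these changes lower the inhibition.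

The compounds shown leave open whether the same change from phenyl to 4-chlorobenzyl would also lower the number with 4-methylphenyl on the nitrogen, where 4-chlorobenzyl gave the highest value of the set. They also leave open how plain benzyl, without the chlorine, or a longer chain such as 2-phenylethyl would behave at this position.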